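Swapping a Hydroxy Chain for a Cyclobutyl Ring

The source may hold more compounds than are shown below. What is called first, only, known or untested is meant among the compounds shown, and "the series" means these compounds.

Measured in a functional assay on HT-29 cells (Homo sapiens) for inhibition, read by luminescence and CellTiter-Glo, with a stated time of 24 h; a higher number here means that more compound is needed for the effect, a lower number that less compound is needed:
Compound 1 `CCCCCn1nc(C(=O)N[C@H]2COc3ccccc3N(C)C2=S)nc1Cc1ccccc1`: 805 nM
Compound 2 `CN1C(=S)[C@@H](NC(=O)c2nc(Cc3ccccc3)n(CCCO)n2)COc2ccccc21`: 209 nM

Of these two, compound 2 has the lower number, 209 nM, so less of it is needed for the effect. Compound 3 `CN1C(=S)[C@@H](NC(=O)c2nc(Cc3ccccc3)n(C3CCC3)n2)COc2ccccc21` differs from it by one change: cyclobutyl in place of 3-hydroxypropyl on an aromatic nitrogen. Among the measured compounds shown here, only one measured step bears on this, a modest one: a 3.9-fold lower number from compound 1 to compound 2 (0.59 log units; beyond the scatter), with hydroxy in place of ethyl on the chain. For the measured compounds named here, compound 3 has no hydroxy, so a rise in the number is expected, probably a smaller one, though no measured compound carries a cyclobutyl ring. In this assay the expected step is a 2.2-fold higher number from compound 2 to compound 3 (0.33 log units; beyond the scatter). The estimate for compound 3 is 450 nM, with an expected range from 130 nM to 1500 nM.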

Compound 3, half-maximal effective concentration: 181 nM
Compound 3: the middle estimate sits 2.5-fold (0.40 log units) above what was measured; low and high end bracket the measured number.
By their numbers in this assay, from the lowest: compounds 3 and 2 (each within the scatter of the next); then compound 1.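

In this assay, replacing 3-hydroxypropyl with cyclobutyl gives a 1.2-fold lower number from compound 2 to compound 3 (0.06 log units; within the scatter), so at this aromatic nitrogen the hydroxy group is not required to keep the number in this range. Replacing pentyl with cyclobutyl gives a 4.4-fold lower number from compound 1 to compound 3 (0.65 log units; beyond the scatter), which shows that a hydroxy-bearing chain is not the only replacement for pentyl that lowers the number. No available evidence explains either step.

From the compounds shown here alone, whether a cyclopentyl ring, a cyclopropyl ring or a chain ending in an amine would fit this position equally well remains open.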